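Adding a second fluoro to compound 3

The source may hold more compounds than are shown below. What is called first, only, known or untested is meant among the compounds shown, and "the series" means these compounds.

In a functional assay, read by spectrophotometry, with a stated time of 30 min (on this read-out lower numbers stand for stronger inhibition and higher numbers for weaker inhibition), compound 1 `Cc1ccccc1CN1CCC(CCNC(=O)/C=C/c2cc(C(C)(C)C)c(O)c(C(C)(C)C)c2)CC1` reads 65300 nM while compound 2 `Cc1ccc(CN2CCC(CCNC(=O)/C=C/c3cc(C(C)(C)C)c(O)c(C(C)(C)C)c3)CC2)cc1` reads 60400 nM and compound 3 `CC(C)(C)c1cc(/C=C/C(=O)NCCC2CCN(Cc3ccccc3F)CC2)cc(C(C)(C)C)c1O` reads 55900 nM on the same scale. These numbers lie within the scatter of one another, so compound 3 stands level with the other two. Compound 4 `CC(C)(C)c1cc(/C=C/C(=O)NCCC2CCN(Cc3ccc(F)cc3F)CC2)cc(C(C)(C)C)c1O` differs from compound 3 by one change (fluoro in place of hydrogen on an aromatic carbon) in the form of fluoro in place of hydrogen on an aromatic carbon, turning 2-fluorobenzyl into 2,4-difluorobenzyl. Among the measured compounds shown here, three measured steps bear on it, each on that same aromatic ring: a 1.1-fold lower number from compound 1 to compound 2 (0.03 log units; within the scatter) and a 1.2-fold lower number from compound 1 to compound 3 (0.07 log units; within the scatter) and a 1.1-fold lower number from compound 2 to compound 3 (0.03 log units; within the scatter) are all small and within the scatter. No step beyond the scatter is therefore expected in this assay in either direction. The expected size is a 1.0-fold lower number from compound 3 to compound 4 (0.01 log units; within the scatter) in this estimate. Compound 4 is estimated at 55000 nM with a range from 28000 nM to 100000 nM as the expected bounds.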

Compound 4, half-maximal inhibitory concentration: 62400 nM
The estimate for compound 4 lay 1.1-fold (0.05 log units) below the measured number; the range from low to high includes it.
By their numbers in this assay, from the lowest: compounds 3, 2, 4 and 1 (each within the scatter of the next).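

Among the compounds shown here, this step adds a second group to the ring, where the earlier steps only exchanged one group for another. Placing the new fluoro para to a large group gives a 1.1-fold higher number from compound 3 to compound 4 (0.05 log units; within the scatter) in this assay, so the addition leaves the reading within the scatter. The steps of a 1.0-fold higher number from compound 2 to compound 4 (0.01 log units; within the scatter) and a 1.0-fold lower number from compound 1 to compound 4 (0.02 log units; within the scatter) also stay within the scatter, and no measurement at hand accounts for this flat result. As far as these compounds go, whether an amine, a carboxylic acid or a methoxy at this position would take the number beyond the scatter remains open.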